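The source may hold more compounds than are shown below. What is called first, only, known or untested is meant among the compounds shown, and "the series" means these compounds.

Measured in a functional assay on T47D cells (Homo sapiens) for cytotoxicity, read by MTT assay, with a stated time of 2 days; on this read-out higher numbers stand for weaker inhibition and lower numbers for stronger inhibition:
compound 1 (`Cc1ccc2c(=O)[nH]c(-c3cccc(F)c3)nc2c1`): > 50000 nM (a limit)
compound 2 (`COc1cccc(-c2nc3cc(C)ccc3c(=O)[nH]2)c1`): > 50000 nM (a limit)
compound 3 (`Cc1ccc2c(=O)[nH]c(-c3cccc(OC(F)(F)F)c3)nc2c1`): > 50000 nM (a limit)

Compound 3 stands at > 50000 nM and this is a limit, not a number. The whole series sits at the limit of > 50000 nM in this assay, at which 3 of the 3 values shown sit, and no order can be drawn among compound 1, compound 2 and compound 3.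

Compound 4 (`Cc1ccc2c(=O)[nH]c(-c3cccc(C(F)(F)F)c3)nc2c1`) carries trifluoromethyl in place of trifluoromethoxy on an aromatic carbon. The measured steps that bear on this change are those at the same place. Both a step that the two limits leave unreadable from compound 1 to compound 3 and a step that the two limits leave unreadable from compound 2 to compound 3 give no size, and a step that the two limits leave unreadable from compound 1 to compound 2 gives none either. Fluoro, methoxy and trifluoromethoxy at this place all leave the compounds at the limit, and no compound measured so far goes against this. No step beyond the scatter is therefore expected in this assay, and no direction can be named. The expectation rests on compound 3 (> 50000 nM), which offers only a limit as its starting point. The expected change is a number no higher from compound 3 to compound 4 (the limit leaves the size open) and it remains an estimate. Compound 4 is estimated at 50000 nM with an expected range from 20000 nM to 100000 nM (most likely reported only as a limit).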

Compound 4, half-maximal inhibitory concentration: > 50000 nM
Compound 4 gave a limit, no number; the forecaster's own chance of this, stated with the estimate: 80%; the middle value lies on the limit itself.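

In this assay compound 4 gives > 50000 nM as a limit, not a number. No new step can be read among compound 1, compound 2, compound 3 and compound 4: the limit of > 50000 nM in this assay, at which 4 of the 4 values shown sit.
The compounds shown leave open how these four compare in strength, and whether any group at this place on the shared core gives a value short of the limit.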